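Branching at the Chain Carbon: Compound 2 to Compound 3

A few compounds are considered here, and "the series" means these few. Any claim that something is new, unique, unknown or untested is made for them only; others in the source may bear on it.

Measured so far in a functional assay on the whole organism (strain Sprague-Dawley albino) with Rattus norvegicus as the target, with a stated time of 0.5 h; on this read-out higher numbers stand for an effect only at larger amounts of compound and lower numbers for an effect already at smaller amounts:
- compound 1 `CCC(C)C(COC(N)=O)C(C)C` gives 114 mg/kg
- compound 2 `CCC(COC(N)=O)C(C)C` gives 81 mg/kg

The two measured compounds share one core and differ only in the group on a saturated chain carbon bound to two saturated chain carbons. Compound 2 holds the lowest of the two numbers in this assay, and its nearest neighbour is compound 1, which stands only a small distance away: a 1.4-fold lower number from compound 1 to compound 2 (0.15 log units; within the scatter). That step lies within the scatter, so the two values cannot be ranked against each other.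

Compound 3 `CC(C)C(COC(N)=O)C(C)C` has not yet been measured. It differs from compound 2 as follows: methyl in place of hydrogen on a saturated chain carbon bound to two saturated chain carbons. For the measured compounds named here, the only step that bears on this change is the one from compound 1 to compound 2, which also swaps a small saturated group for hydrogen at the same place and which stayed within the scatter. On that basis a step in this assay beyond the scatter is not expected, in either direction. Compound 3 is therefore estimated at 90 mg/kg, with a range from 55 mg/kg to 150 mg/kg. The expected step from compound 2 amounts to a 1.1-fold higher number from compound 2 to compound 3 (0.05 log units; within the scatter).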

Compound 3, dose for half-maximal effect: 94 mg/kg
The estimate for compound 3 lay 1.0-fold (0.02 log units) below the measured number; measured number inside the range.
By their numbers in this assay, from the lowest: compounds 2, 3 and 1 (each within the scatter of the next).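

In this assay, methyl in place of hydrogen on a saturated chain carbon bound to two saturated chain carbons, which cut one bond further out reads as ethyl to isopropyl, gives a 1.2-fold higher number from compound 2 to compound 3 (0.06 log units; within the scatter). For the compounds shown here, the third compound also adds a step that the first two could not offer, a 1.2-fold lower number from compound 1 to compound 3 (0.08 log units; within the scatter), so hydrogen, methyl and ethyl at this place now form a set of three in which no pair can be ranked against each other, and a single added carbon in either of the two new steps leaves the number within the scatter. The compounds come with no independent measurement that would explain why this position tolerates these changes.

Going by these compounds, whether a longer chain such as hexyl, a phenyl ring, or an amine or a carboxylic acid at this place would move the number beyond the scatter remains open. The three compounds also leave unanswered what a change elsewhere on the shared core would do in this assay.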